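A few compounds are considered here, and "the series" means these few. Any claim that something is new, unique, unknown or untested is made for them only; others in the source may bear on it.

Three measured compounds share a fused core and differ in small ways. Compound 1 `ClCc1ccccc1Cn1cnc2c(Cl)nc(Cl)nc21` and compound 2 `ClCc1cccc(Cn2cnc3c(Cl)nc(Cl)nc32)c1` are built from the same atoms joined differently, and the difference between these two cores is not broken down here. In a functional assay on OVCAR-8 cells (Homo sapiens) for cytotoxicity, read by sulforhodamine B assay, with a stated time of 48 h (a higher number here means a weaker inhibitor of growth, a lower number a stronger inhibitor of growth), compound 1 gives 1230 nM, while compound 2 gives 1820 nM, and these two values lie within the usual scatter of each other. Compound 3 `Nc1nc(Cl)c2ncn(Cc3ccccc3CCl)c2n1` is compound 1 with one group exchanged (amino in place of chloro on an aromatic carbon). In this assay compound 3 gives 3890 nM, so this exchange brought a 3.2-fold higher number from compound 1 to compound 3 (0.50 log units; beyond the scatter). Compound 4 `Nc1nc(Cl)c2ncn(Cc3cccc(CCl)c3)c2n1` carries the same exchange on the core of compound 2 (amino in place of chloro on an aromatic carbon), and the surroundings of the place are described in the same words for both pairs, so it is the same change. For the measured compounds named here, for compound 4 the expected step is a 3.2-fold higher number from compound 2 to compound 4 (0.50 log units; beyond the scatter), because the one earlier example of this change gave a 3.2-fold higher number from compound 1 to compound 3 (0.50 log units; beyond the scatter). In this assay compound 4 is therefore expected to give about 5800 nM. For compound 4 the estimate is most likely to fall between 2700 nM and 12500 nM.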

Compound 4, concentration for 50% growth inhibition: 2290 nM
Beside the measured number, compound 4's estimate is 2.5-fold (0.40 log units) above it, outside the stated range (below it).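

In this assay, for the compounds shown here, amino in place of chloro on an aromatic carbon brought a 1.3-fold higher number from compound 2 to compound 4 (0.10 log units; within the scatter), so on this core the exchange produced no step that can be told apart from the ordinary scatter of repeated measurements. Set beside the earlier example, the two steps do not separate from each other: the same change on two cores in this assay, a 3.2-fold higher number (0.50 log units; beyond the scatter) from compound 1 to compound 3 and a 1.3-fold higher number (0.10 log units; within the scatter) from compound 2 to compound 4, 2.5-fold (0.40 log units) apart, within the scatter of two such steps. This shows that the data give no sign that the two cores respond differently to this change, but two pairs are too few to show that the step has one fixed size that carries reliably from core to core, and they do not explain why one step lies beyond the scatter and the other within it.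

Going by these compounds, what a methoxy or a dimethylamino group would do at the same place, on the aromatic carbon between two ring nitrogen atoms, stays open. Also open, on these data alone, is whether the amino exchange would behave alike on further cores or in other cell lines.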